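The source may hold more compounds than are shown below. What is called first, only, known or untested is meant among the compounds shown, and "the series" means these compounds.

Working notes on the urea series. Compound 1 `COc1cc(Cl)cc(-c2nn(-c3cccc(NC(=O)Nc4ccc(Cl)c(C(F)(F)F)c4)c3)cc2-c2ccncc2)c1` gives 84% in a functional assay on HOP-62 cells (Homo sapiens) for inhibition, read by sulforhodamine B assay, with a stated time of 48 h, tested at 1 uM (a lower number here means a stronger effect, a higher number a weaker effect of the compound at the concentration tested), compound 2 `COc1cc(Cl)cc(-c2nn(-c3cccc(NC(=O)Nc4cc(C(F)(F)F)cc(C(F)(F)F)c4)c3)cc2-c2ccncc2)c1` gives 40%, and compound 3 `COc1cc(Cl)cc(-c2nn(-c3cccc(NC(=O)Nc4ccc(Cl)c(Cl)c4)c3)cc2-c2ccncc2)c1` gives 91%. Compound 3 has the highest of the three numbers; compound 1 lies within the scatter of it, while compound 2 lies well beyond it. Among the compounds with values here, the only one-place step measured, a number 7 percentage points higher from compound 1 to compound 3 (within the scatter), is within the scatter. Compound 4 `COc1cc(Cl)cc(-c2nn(-c3cccc(NC(=O)Nc4cccc(C(F)(F)F)c4)c3)cc2-c2ccncc2)c1` is not yet measured; it differs from compound 3 by 3-(trifluoromethyl)phenyl in place of 3,4-dichlorophenyl on an amide-type nitrogen. Within the data shown here, no measured step covers this exact exchange; the step from compound 1 to compound 3 touches the same urea aryl and is small, but compound 2 shows that a second trifluoromethyl group goes with a much lower number. The step of a number 11 percentage points lower from compound 3 to compound 4 (beyond the scatter) is therefore expected to be modest, leaning lower. Compound 4 is estimated at 80%, range 55% to 100%.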

Compound 4, a percentage reported as activity, at one concentration (the size of the read-out at that concentration, not a potency): 85%
Beside the measured number, compound 4's estimate is 5 percentage points below it, and the stated range covers the measured number.
By their numbers in this assay, from the lowest: compound 2; then compounds 1, 4 and 3 (each within the scatter of the next).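

In this assay the exchange on the amide-type nitrogen gives a number 6 percentage points lower from compound 3 to compound 4 (within the scatter) and hydrogen in place of chloro on an aromatic carbon gives a number 1 percentage points higher from compound 1 to compound 4 (within the scatter) and neither change separates these compounds. Taking away one of the two trifluoromethyl groups gives a number 45 percentage points higher from compound 2 to compound 4 (beyond the scatter) and this one-place step now ties the low number of compound 2 to its second trifluoromethyl group. The data at hand give no cause for any of these steps.

From the compounds shown here alone, whether a nitrile or a carboxylic acid in place of that second trifluoromethyl group would also go with a low number stays open. Going by these compounds, whether the same step holds in other cell lines also stays open.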